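From Methylsulfanyl to Ethylsulfanyl: An Expected Step

This account rests on a few compounds, and the source may have more. Where it says the series, first, only, none or still open, it means among the compounds named here.

Compound 1, `O=C(CSC(=S)N[C@H]1CCOC1=O)Nc1cccc([N+](=O)[O-])c1`, gives in a functional assay on EC9706 cells (Homo sapiens) for cytotoxicity, read by MTT assay, with a stated time of 72 h (a lower number here means a stronger inhibitor, a higher number a weaker inhibitor), only a limit of the assay, > 128000 nM.
Compound 2, `CSC(=S)N[C@H]1CCOC1=O`, gives in this assay likewise only a limit, > 128000 nM.

Both of these numbers are limits and not measured values: the limit of > 128000 nM in this assay, at which 2 of the 2 values shown sit. Compound 2 therefore stands at the same limit as compound 1, and the numbers shown do not separate the two. Compound 3, `CCSC(=S)N[C@H]1CCOC1=O`, differs from compound 2 by a single change: methyl in place of hydrogen on a saturated chain carbon bound to a sulfur. For the measured compounds named here, no step between two measured compounds is available here, so the size of this step can only be guessed from the fact that both measured compounds already sit at the limit of this assay. The step that the limit leaves unreadable from compound 2 to compound 3 is expected to be none beyond the usual scatter, and the result for compound 3 is most likely to be reported again as a limit rather than as a number. Compound 3 is thus expected to give 200000 nM in this assay, somewhere between 100000 nM and 600000 nM.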

Compound 3, half-maximal inhibitory concentration: > 128000 nM
Compound 3: no number, only a limit (the forecaster's own chance of this, stated with the estimate: 85%); the middle value is on the limit's open side.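

Compound 2 and compound 3 both end at a limit of the assay rather than at a number, so no step between them can be read: the limit of > 128000 nM in this assay, at which 3 of the 3 values shown sit.

The compounds shown leave open whether going from methylsulfanyl to ethylsulfanyl changes the result in this assay at all, and what true value any of the three compounds has there.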